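Compound 4 in the Bel-7402 series: methoxy and N-methyl

The source may report more compounds than this note shows. Statements on the series, on what has been measured and on what is new or still open speak of the compounds shown alone.

Among the compounds with values here, in a functional assay on Bel-7402 cells (Homo sapiens) for antiproliferative activity, read by MTT assay, with a stated time of 72 h (on this read-out lower numbers stand for stronger inhibition and higher numbers for weaker inhibition), compound 3 `COc1ccc(Cn2c(C(=O)O)c(CNCc3cccc(O)c3)c3ccc(C)cc32)cc1` gives 19800 nM, and this is the only measured number in the set. Compound 1 `COc1ccc(Cn2c(C(=O)O)c(CNCc3cc(OC)ccc3O)c3ccc(C)cc32)cc1` reaches only the limit of the assay, > 50000 nM. Compound 2 `COc1ccc(Cn2c(C(=O)O)c(CNC(=O)c3cccc(OC)c3)c3ccc(C)cc32)cc1` likewise reaches only the limit, > 50000 nM, a point recorded as the limit of > 50000 nM in this assay, at which 2 of the 3 values shown sit. Both steps toward compound 3 therefore read as lower bounds: an at least 2.5-fold lower number from compound 1 to compound 3 (0.40 log units; beyond the scatter), and an at least 2.5-fold lower number from compound 2 to compound 3 (0.40 log units; beyond the scatter). The step between compound 1 and compound 2, a step that the two limits leave unreadable from compound 1 to compound 2, cannot be sized.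

Compound 4 `COc1ccc(Cn2c(C(=O)O)c(CN(C)Cc3cccc(OC)c3)c3ccc(C)cc32)cc1` now moves away from compound 3 in the opposite sense, with (3-methoxybenzyl)(methyl)amino in place of (3-hydroxybenzyl)amino on a saturated chain carbon bound to an aromatic carbon. Within the data shown here, the two readable steps both gave the number with the 3-hydroxybenzyl group as the lowest of the three, so the hydroxy-bearing benzyl appears tied to the one measurable value; compound 4 keeps neither the hydroxy nor the amine hydrogen. An increase in this assay is expected, of a size around a 2.0-fold higher number from compound 3 to compound 4 (0.31 log units; beyond the scatter), and there is a fair chance the assay again reports only its limit. Compound 4 is accordingly estimated at 40000 nM, with a range from 15000 nM to 100000 nM.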

Compound 4, half-maximal inhibitory concentration: 33000 nM
Beside the measured number, compound 4's estimate is 1.2-fold (0.08 log units) above it; the range from low to high includes it.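

In this assay, (3-methoxybenzyl)(methyl)amino in place of (3-hydroxybenzyl)amino gives a 1.7-fold higher number from compound 3 to compound 4 (0.22 log units; within the scatter), so at this position the hydroxy and the amine hydrogen can both go without a step that stands out from the scatter. Within the data shown here, the earlier compounds offered a single measured number, held by the only compound with a 3-hydroxybenzyl group; compound 4 now shows that a measured number does not depend on that group, although compound 1 also carries a hydroxy on its benzyl group and still sits at a limit. The steps from the two compounds at the limit give only floors, an at least 1.5-fold lower number from compound 2 to compound 4 (0.18 log units; that floor lies within the scatter) and an at least 1.5-fold lower number from compound 1 to compound 4 (0.18 log units; that floor lies within the scatter), so neither step separates compound 4 from them by more than the scatter: the limit of > 50000 nM in this assay, at which 2 of the 4 values shown sit.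

On these data alone, the methoxy and the methyl on the amine nitrogen enter together, so what each contributes alone stays open. Also open, as far as these compounds go, is how this assay would read with a 3-aminobenzyl group at this position, or with a methyl ester in place of the carboxylic acid.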